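Configuration flip in a fluorophenyl urea pair

A few compounds are considered here, and "the series" means these few. Any claim that something is new, unique, unknown or untested is made for them only; others in the source may bear on it.

Compound 1 `C[C@H](NC(=O)Nc1ccccc1F)c1ccccc1` and compound 2 `C[C@@H](NC(=O)Nc1ccc(F)cc1F)c1ccccc1` have been measured in an ADME assay on the whole organism with Oryza sativa as the target, tested at 0.1 uM; a lower number here means a stronger effect, a higher number a weaker effect of the compound at the concentration tested. In this assay compound 1 gives 98%, while compound 2 gives 100%, the higher of the two numbers, though its nearest neighbour compound 1 sits within the scatter of it. Compound 3 `C[C@H](NC(=O)Nc1ccc(F)cc1F)c1ccccc1` is the next candidate. Its change from compound 2 is the two compounds have the same atoms and bonds and differ only in configuration as drawn: 1 of 1 stereo elements differ; a stereocentre at a saturated chain carbon is drawn R in compound 2 and S in compound 3. Within the data shown here, no measured pair in the set shows such a configuration change, so no step beyond the scatter is assumed in either direction. The expected step is a number 5 percentage points lower from compound 2 to compound 3 (within the scatter). In this assay compound 3 is estimated at 95%, within 80% to 100%.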

Compound 3, a percentage reported as activity, at one concentration (the size of the read-out at that concentration, not a potency): 101%
Compound 3: middle estimate off by 6 percentage points, on the low side, outside the stated range (above it).
By their numbers in this assay, from the lowest: compounds 1, 2 and 3 (each within the scatter of the next).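

In this assay, the configuration at the saturated chain carbon now has a measured pair, and its step is a number 1 percentage points higher from compound 2 to compound 3 (within the scatter), so this stereocentre drawn R or S gives no readable difference at the tested concentration. This pair isolates that single change: the fact that compounds 2 and 3 differ only in the configuration as drawn. Fluoro in place of hydrogen on an aromatic carbon gives a number 3 percentage points higher from compound 1 to compound 3 (within the scatter), so this change also stays inside the scatter.

Open, going by these compounds, is whether any other group moves this assay beyond the scatter, for example a carboxylic acid or a methoxy group in place of the fluoro.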